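Swapping a seven-membered ring for a five-membered one

The source may hold more compounds than are shown below. What is called first, only, known or untested is meant among the compounds shown, and "the series" means these compounds.

In a functional assay on DU-145 cells (Homo sapiens) for inhibition, read by MTT assay, with stated times of 18 h and 4 h (on this read-out higher numbers stand for weaker inhibition and lower numbers for stronger inhibition), compound 1 (`CCCCCCCCCCOP(=O)(O)OCCSC(=S)N1CCCC1`) gives 46100 nM. Compound 3 (`CCCCCCOP(=O)(O)OCCSC(=S)N1CCCCCC1`) gives 77400 nM, which lies within the usual scatter of the number for compound 1. For compound 2 (`CCCOP(=O)(O)OCCSC(=S)N1CCCC1`) this assay gives only a limit, > 100000 nM.

Compound 4 (`CCCCCCOP(=O)(O)OCCSC(=S)N1CCCC1`) keeps the chain of compound 3 and changes one group: pyrrolidin-1-yl in place of azepan-1-yl on a thiocarbonyl carbon. Put simply, pyrrolidin-1-yl stands in place of azepan-1-yl on a thiocarbonyl carbon.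

Among the compounds with values here, no measured pair shows this ring change alone, so the evidence is indirect. Within the data shown here, the one measured step alters the chain instead, with hydrogen in place of heptyl on a saturated chain carbon, and it gives an at least 2.1-fold higher number from compound 1 to compound 2 (0.33 log units; beyond the scatter). Compound 4 has the pyrrolidin-1-yl of compounds 1 and 2, with a chain shorter than in compound 1 and longer than in compound 2. Its number is therefore expected to fall within the span of an at least 2.1-fold higher number from compound 1 to compound 2 (0.33 log units; beyond the scatter), close to the number for compound 3. The expected change is a 1.0-fold higher number from compound 3 to compound 4 (0.01 log units; within the scatter), which would not stand beyond the scatter. Compound 4 is estimated at 80000 nM, with an expected range from 45000 nM to 140000 nM.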

Compound 4, half-maximal inhibitory concentration: > 100000 nM
Compound 4: only a limit was reported (the forecaster's own chance of this, stated with the estimate: 30%); middle value at least 1.2-fold (0.09 log units) from the limit.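

In this assay, compound 4 gives > 100000 nM, which is a limit of the assay and not a number. The change of pyrrolidin-1-yl for azepan-1-yl on a thiocarbonyl carbon gives an at least 1.2-fold higher number from compound 3 to compound 4 (0.11 log units; that floor lies within the scatter), so this first direct view of the ring change shows no firm loss, although a larger one remains possible. With pyrrolidin-1-yl held in place, the shorter chain gives an at least 2.1-fold higher number from compound 1 to compound 4 (0.33 log units; beyond the scatter), so the longer chain of compound 1 gives stronger inhibition than the chain of compound 4, while the step between compound 2 and compound 4 cannot be read.

As far as these compounds go, the true number for compound 4 stays open, and the series runs into the same limit more than once: the limit of > 100000 nM in this assay, at which 2 of the 4 values shown sit. Still unanswered is how the longer chain of compound 1 would behave with azepan-1-yl on the thiocarbonyl carbon, which could show the ring change between two real numbers, and how a piperidin-1-yl or dimethylamino group would compare there.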